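The source may report more compounds than this note shows. Statements on the series, on what has been measured and on what is new or still open speak of the compounds shown alone.

Working notes on the series.

Compound 1 `COc1ccccc1/C=C(\C(=O)c1ccc(Cl)cc1)S(=O)(=O)Cc1ccc(Cl)c(Cl)c1` is the anchor of the set. In a functional assay on DU-145 cells (Homo sapiens) for inhibition, read by trypan blue exclusion, with a stated time of 96 h (on this read-out higher numbers stand for weaker inhibition of growth and lower numbers for stronger inhibition of growth), compound 1 gives 1000 nM. Within the data shown here, compound 2 `COc1ccccc1/C=C(\C(=O)c1ccc(Cl)cc1)S(=O)(=O)c1ccc(Br)cc1` differs from it in one place, (4-bromophenyl in place of 3,4-dichlorobenzyl on a sulfonyl sulfur), and in this assay compound 2 gives 10000 nM; the step of a 10-fold higher number from compound 1 to compound 2 (1.00 log units; beyond the scatter) is the only measured step for this change in the set.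

Compound 3 `O=C(/C(=C\c1c(O)cc(O)cc1O)SCc1ccc(Cl)c(Cl)c1)c1ccc(Cl)cc1` belongs to a second core. How the core of compound 3 differs from the core of compound 1 is not broken down here. In this assay compound 3 gives 25000 nM, the highest number of the three measured compounds.

Compound 4 `O=C(/C(=C\c1c(O)cc(O)cc1O)Sc1ccc(Br)cc1)c1ccc(Cl)cc1` is not yet measured. It differs from compound 3 by 4-bromophenyl in place of 3,4-dichlorobenzyl on a sulfur. Among the measured compounds shown here, this is the same kind of change as the one from compound 1 to compound 2, not the same change: there the new group sits on a sulfonyl sulfur whose other neighbours are a double-bonded chain carbon, here on a sulfur whose other neighbours are a double-bonded chain carbon.

The step from compound 3 to compound 4 in this assay is expected to be a 2.8-fold higher number from compound 3 to compound 4 (0.45 log units; beyond the scatter), in the same direction as the earlier step but judged less firmly because a 10-fold higher number from compound 1 to compound 2 (1.00 log units; beyond the scatter) was seen on a different core and a different sulfur. Compound 4 is therefore expected to give about 70000 nM in this assay, with a plausible range from 20000 nM to 250000 nM.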

Compound 4, concentration for 50% growth inhibition: 50000 nM
Estimate against measurement, compound 4: 1.4-fold (0.15 log units) above, within the range that was stated.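

In this assay, placing 4-bromophenyl where 3,4-dichlorobenzyl stood on the sulfur gives a 2.0-fold higher number from compound 3 to compound 4 (0.30 log units; within the scatter), so on this core the change does not separate the pair beyond the usual variation between repeats. The change therefore does not carry over from one core to the other with the size it had on the core of compound 1: the same change on two cores in this assay, a 10-fold higher number (1.00 log units; beyond the scatter) from compound 1 to compound 2 and a 2.0-fold higher number (0.30 log units; within the scatter) from compound 3 to compound 4, 5.0-fold (0.70 log units) apart, beyond the scatter of two such steps

This does not show what sets the two steps apart. The pairs differ both in the core and in the state of the sulfur, a sulfonyl sulfur in one pair and a plain sulfur in the other, and each step rests on a single pair of compounds, so the core and the sulfur cannot be told apart as the source of the gap.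

The compounds shown leave open how the step behaves when only one of these two features varies, with the core held fixed and the sulfur changed, or the reverse. They also leave open how other groups on the sulfur would fare, such as an unsubstituted benzyl, a longer chain ending in an aryl ring, or a chain carrying an amine or a carboxylic acid.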